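This account rests on a few compounds, and the source may have more. Where it says the series, first, only, none or still open, it means among the compounds named here.

The series shares the core of compound 1 `COc1cccc(OC)c1C(=O)Nc1c[nH]nc1C(=O)Nc1ccncc1`. In an ADME assay on MRC5 cells (Homo sapiens) for inhibition, with a stated time of 72 h (a lower number here means that less compound is needed, a higher number that more compound is needed for the effect), compound 1 gives > 50000 nM, which is a limit of the assay and not a number. Compound 3 `COc1cccc(OC)c1C(=O)Nc1c[nH]nc1C(=O)NC1CCN(C(=O)OC(C)(C)C)CC1` also sits at a limit: in this assay compound 3 gives > 50000 nM. Going by the values given here, compound 2 `CO[C@H]1CC[C@H](NC(=O)c2n[nH]cc2NC(=O)c2ccc(-c3ccccc3)o2)CC1` is the only one with a number, and in this assay compound 2 gives 100 nM. Where compound 1 stands is therefore set by the limit of > 50000 nM in this assay, at which 2 of the 3 values shown sit; no step between measured compounds can be read off, since no two of them differ in one place only.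

Compound 4 `COc1cccc(OC)c1C(=O)Nc1c[nH]nc1C(=O)O` differs from compound 1 as follows: hydroxy in place of (pyridin-4-yl)amino on a carbonyl carbon. With compound 1 already at a limit, the step expected in this assay is a step that the limit leaves unreadable from compound 1 to compound 4, which amounts to no movement that the assay could resolve. For compound 4 the expected value in this assay is estimated at 80000 nM, with a range from 30000 nM to 200000 nM, and it is expected most likely to come back as a limit once more.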

Compound 4, half-maximal effective concentration: > 50000 nM
Compound 4: a limit, no number (the forecaster's own chance of this, stated with the estimate: 90%); the middle value lies beyond the limit too.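

Compound 4, like compound 1, sits at a limit and not at a number, so no step between the two can be read in this assay: the limit of > 50000 nM in this assay, at which 3 of the 4 values shown sit.

The compounds shown leave open whether hydroxy in place of (pyridin-4-yl)amino moves the value at all.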